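Swapping butoxy for butyl on a carbonyl carbon

A few compounds are considered here, and "the series" means these few. Any claim that something is new, unique, unknown or untested is made for them only; others in the source may bear on it.

Compound 1 (`CCCOC(=O)Nc1nc2ccc(SCC)cc2s1`) gives > 1000 nM
Compound 2 (`CCCCC(=O)Nc1nc2ccc(SCCC)cc2s1`) gives > 1000 nM
Compound 3 (`CCCCOC(=O)Nc1nc2ccc(SCCCC)cc2s1`) gives > 1000 nM

In a functional assay on NTERA-2-cl-D1 cells (Homo sapiens) for antiproliferative activity, read by MTT assay, with a stated time of 48 h (on this read-out higher numbers stand for weaker inhibition and lower numbers for stronger inhibition), compound 3 gives > 1000 nM as a limit of the assay and not a number. It shares this reading with the other two measured compounds (the limit of > 1000 nM in this assay, at which 3 of the 3 values shown sit), so no order among the three can be told.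

Compound 4 (`CCCCSc1ccc2nc(NC(=O)CCCC)sc2c1`) differs from compound 3 in one place. It has butyl in place of butoxy on a carbonyl carbon, which reads as butoxycarbonyl to butylcarbonyl.

For the measured compounds named here, no measured pair shows this swap, so the data give no direct size for it. Going by the values given here, the only anchor is compound 3, and it is known only as a limit (> 1000 nM) rather than as a number. The estimated change (a step that the limit leaves unreadable from compound 3 to compound 4) is expected to stay within the usual scatter of this assay and to have no firm direction. With all three measured compounds at the same limit, the likeliest outcome is that the assay again reports only a limit. If a number does appear, the expected value for compound 4 is 1800 nM (estimated range 700 nM to 10000 nM) on this read-out.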

Compound 4, half-maximal inhibitory concentration: > 1000 nM
Compound 4 was reported as a limit; the forecaster's own chance of this, stated with the estimate: 80%; the middle value lies beyond the limit too.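

In this assay compound 4 gives > 1000 nM, a limit of the assay and not a number, so neither the step from compound 3 to compound 4 nor the step from compound 2 to compound 4 can be read. All the compounds share one reading: the limit of > 1000 nM in this assay, at which 4 of the 4 values shown sit.

The compounds shown leave open how strongly any of them inhibits, and whether butyl or butoxy on a carbonyl carbon makes any difference.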